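A few compounds are considered here, and "the series" means these few. Any claim that something is new, unique, unknown or untested is made for them only; others in the source may bear on it.

Compound 1 `O=C1C[C@H](OCc2cn(-c3ccc([N+](=O)[O-])cc3)nn2)[C@H]2CO[C@@H]1O2`: 18300 nM
Compound 2 `O=C1C[C@H](OCc2cn(-c3ccc(Cl)cc3)nn2)[C@H]2CO[C@@H]1O2`: 14700 nM

Both numbers come from a functional assay on HT-29 cells (Homo sapiens) for cytotoxicity, read by MTT assay, with a stated time of 48 h; a higher number here means a weaker inhibitor, a lower number a stronger inhibitor. In this assay, among the compounds with values here, compound 2 stands level with compound 1, since the only measured step, a 1.2-fold lower number from compound 1 to compound 2 (0.10 log units; within the scatter), is within the scatter. Compound 3 `O=C1C[C@H](OCc2cn(-c3ccccc3)nn2)[C@H]2CO[C@@H]1O2` differs from compound 2 by hydrogen in place of chloro on an aromatic carbon. That measured step exchanged a group at the same aromatic carbon and stayed within the scatter, so no step beyond the scatter is expected here either. Compound 3 is therefore expected to give 18000 nM in this assay, with a range from 7000 nM to 45000 nM. This expectation amounts to a 1.2-fold higher number from compound 2 to compound 3 (0.09 log units; within the scatter).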

Compound 3, half-maximal inhibitory concentration: 13400 nM
Compound 3: the middle estimate sits 1.3-fold (0.13 log units) above what was measured; measured number inside the range.
By their numbers in this assay, from the lowest: compounds 3, 2 and 1 (each within the scatter of the next).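

In this assay taking the ring substituent away altogether, rather than exchanging it, stays within the scatter for both chloro (a 1.1-fold lower number from compound 2 to compound 3 (0.04 log units; within the scatter)) and nitro (a 1.4-fold lower number from compound 1 to compound 3 (0.14 log units; within the scatter)). At this carbon, para to a large group, the unsubstituted phenyl of compound 3 therefore stands level with both substituted compounds, so neither group shows a measurable gain over hydrogen. No measured evidence bears on why these numbers lie so close. On these data alone, whether an amine or a carboxylic acid at this carbon would move the number beyond the scatter stays open, as does the effect of chloro at another carbon of the ring.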